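Epimer of compound 2 awaits its antiproliferative result

The source may hold more compounds than are shown below. What is called first, only, known or untested is meant among the compounds shown, and "the series" means these compounds.

Values in a functional assay on KARPAS-422 cells (Homo sapiens) for antiproliferative activity, read by resazurin assay, with a stated time of 72 h (on this read-out lower numbers stand for stronger inhibition and higher numbers for weaker inhibition), so far:
Compound 1 `COC(c1cc(Cl)c2c(c1Cl)C(=O)N(Cc1c(C)cc(C)[nH]c1=O)CC2)C1CCOCC1` gives 1150 nM; 19 nM (2 entries)
Compound 2 `Cc1cc(C)c(CN2CCc3c(Cl)cc([C@H](CO)[C@H]4CCCO4)c(Cl)c3C2=O)c(=O)[nH]1` gives 63 nM

Compound 2 has this single number and one further entry without a single number. Its value lies within the wide spread of compound 1 (the several entries of compound 1 in this assay, 1150 nM; 19 nM (2 entries)). Compound 3 `Cc1cc(C)c(CN2CCc3c(Cl)cc([C@H](CO)[C@@H]4CCCO4)c(Cl)c3C2=O)c(=O)[nH]1` differs from compound 2 only in configuration (the two compounds have the same atoms and bonds and differ only in configuration as drawn: 1 of 2 stereo elements differ; a stereocentre at a saturated ring carbon is drawn R in compound 2 and S in compound 3). Among the measured compounds shown here, no measured pair shows such a change, so its size is uncertain. A small weakening is expected, about the size of the usual scatter (a 1.6-fold higher number from compound 2 to compound 3 (0.20 log units; within the scatter)). For compound 3 the estimated value is 100 nM and the expected range runs from 20 nM to 500 nM in this assay once measured.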

Compound 3, half-maximal inhibitory concentration: 57 nM
The estimate for compound 3 lay 1.8-fold (0.24 log units) above the measured number; the measured number falls inside the stated range.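

In this assay the inversion gives a 1.1-fold lower number from compound 2 to compound 3 (0.04 log units; within the scatter), so at this saturated ring carbon the R and S drawings read alike. This is the first pair shown that isolates configuration at this position: the fact that compounds 2 and 3 differ only in the configuration as drawn. The result therefore gives this stereocentre no visible bearing on antiproliferative activity within the usual scatter of this read-out.

From the compounds shown here alone, the other stereo element, shared by compound 2 and compound 3, remains untested by this pair. Also open, going by these compounds, is how a ring bearing an amine would read at this position.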